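Notes on the aromatic substituent step to compound 4

The compounds below may be only part of what the source reports. "The series", "measured", "known", "first", "only" and "open" are said of these compounds alone.

Measured so far:
compound 1 `CC(C)(C)OC(=O)NCCNC(=O)CN1CN(c2ccccc2)C2(CCN(C(=O)c3ccc(C(C)(C)C)cc3)CC2)C1=O` — 10900 nM
compound 2 `CC(C)(C)c1ccc(C(=O)N2CCC3(CC2)C(=O)N(CC(=O)NCCN)CN3c2ccccc2)cc1` — 7000 nM
compound 3 `NC(=O)C1CCCN(C(=O)CN2CN(c3ccccc3)C3(CCN(C(=O)c4ccc(C5CCCCC5)cc4)CC3)C2=O)C1` — 3100 nM

In an assay on HEK293 cells for displacement of a labelled ligand from NPC1-like intracellular cholesterol transporter 1 (Homo sapiens) (on this read-out higher numbers stand for weaker inhibition and lower numbers for stronger inhibition), compound 3 gives the lowest number of the three, with compound 2 as its nearest neighbour and compound 1 furthest away, both gaps beyond the scatter. Going by the values given here, the only step between measured compounds that differ in one place is a 1.6-fold lower number from compound 1 to compound 2 (0.19 log units; within the scatter), hydrogen in place of tert-butoxycarbonyl on an amine nitrogen, and it concerns the side chain, not the aromatic substituent.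

Compound 4 `CC(C)(C)c1ccc(C(=O)N2CCC3(CC2)C(=O)N(CC(=O)N2CCCC(C(N)=O)C2)CN3c2ccccc2)cc1` differs from compound 3 by tert-butyl in place of cyclohexyl on an aromatic carbon. Among the compounds with values here, no measured step bears on this change; compounds 1 and 2 carry tert-butyl but also a different side chain, so their values cannot be separated into the two contributions. The expectation for a 1.3-fold higher number from compound 3 to compound 4 (0.11 log units; within the scatter) is therefore no step beyond the scatter, with the range widened for the missing precedent. Compound 4 is estimated at 4000 nM, within 1500 nM to 11000 nM.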

Compound 4, half-maximal inhibitory concentration: 16900 nM
Estimate against measurement, compound 4: 4.2-fold (0.63 log units) below; the measured number lies above the stated range.
By their numbers in this assay, from the lowest: compound 3; then compounds 2, 1 and 4 (each within the scatter of the next, the first and the last beyond it).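

Going by these compounds alone, with the 3-carbamoylpiperidin-1-yl side chain held fixed in this assay, the change from 4-cyclohexylphenyl to 4-(tert-butyl)phenyl gives a 5.5-fold higher number from compound 3 to compound 4 (0.74 log units; beyond the scatter), the first single-place change to go beyond the scatter, so the number responds to the group at this position. With tert-butyl held fixed, the side-chain changes give a 2.4-fold higher number from compound 2 to compound 4 (0.38 log units; beyond the scatter) and a 1.6-fold higher number from compound 1 to compound 4 (0.19 log units; within the scatter), so on the tert-butyl compounds the 3-carbamoylpiperidin-1-yl side chain shows no advantage over either open-chain side chain. Nothing available explains the size of the step from cyclohexyl to tert-butyl.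

As far as these compounds go, whether the ring or the size of the group carries this step stays open, and a hexyl chain or a phenyl group at this place would help separate the two. Also open, from the compounds shown here alone, is whether cyclohexyl gives a similar step on the (2-aminoethyl)amino side chain.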